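This account rests on a few compounds, and the source may have more. Where it says the series, first, only, none or still open, it means among the compounds named here.

In an assay on CHO cells for antagonist activity at transient receptor potential cation channel subfamily V member 1 (Homo sapiens), read by FLIPR (on this read-out higher numbers stand for weaker inhibition and lower numbers for stronger inhibition), compound 1 `CC(C(=O)NCc1ccc(C(F)(F)F)cc1N1CCC(C(F)(F)F)CC1)c1ccc(NS(C)(=O)=O)c(F)c1` gives 0.4 nM and compound 2 `CC(C(=O)NCc1ccc(C(F)(F)F)cc1SC1CCCC1)c1ccc(NS(C)(=O)=O)c(F)c1` gives 0.3 nM. Compound 2 has the lower of the two numbers, yet a 1.3-fold lower number from compound 1 to compound 2 (0.12 log units; within the scatter), so the two stand together. Compound 3 `CC(C(=O)NCc1ccc(C(F)(F)F)cc1-c1cccnc1)c1ccc(NS(C)(=O)=O)c(F)c1` carries pyridin-3-yl in place of cyclopentylsulfanyl on an aromatic carbon. Among the compounds with values here, the one measured step swapped two non-aromatic groups and moved nothing beyond the scatter; no measured step covers an aromatic ring entering here, so guidance is thin and no shift beyond the scatter is expected in either direction. Compound 3 is therefore expected at 0.8 nM, in a range from 0.15 nM to 5 nM, which means a 2.7-fold higher number from compound 2 to compound 3 (0.43 log units; beyond the scatter).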

Compound 3, inhibition constant: 59.4 nM
The estimate for compound 3 lay 74-fold (1.87 log units) below the measured number; the measured number lies above the stated range.
By their numbers in this assay, from the lowest: compounds 2 and 1 (each within the scatter of the next); then compound 3.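

In this assay, the position on an aromatic carbon ortho to a large group proves far from indifferent to its substituent: pyridin-3-yl in place of cyclopentylsulfanyl gives a 200-fold higher number from compound 2 to compound 3 (2.30 log units; beyond the scatter), and in place of 4-(trifluoromethyl)piperidin-1-yl gives a 150-fold higher number from compound 1 to compound 3 (2.17 log units; beyond the scatter). The heavy-atom and hydrogen-bond acceptor counts match those of cyclopentylsulfanyl, so these counts alone do not track the change. No available evidence accounts for this rise. As far as these compounds go, whether it follows the aromatic ring itself or its ring nitrogen stays open; phenyl at this position would separate the two.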